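A few compounds are considered here, and "the series" means these few. Any claim that something is new, unique, unknown or untested is made for them only; others in the source may bear on it.

In an assay on CHO-K1 cells for antagonist activity at transient receptor potential cation channel subfamily V member 1 (Homo sapiens), read by FLIPR (on this read-out lower numbers stand for stronger inhibition and higher numbers for weaker inhibition), compound 2 `CC(C(=O)NCc1ccc(C(F)(F)F)nc1SCCCN1CCCCC1)c1ccc(NS(C)(=O)=O)c(F)c1` gives 3 nM. Within the data shown here, the only other compound measured, compound 1 `CC(C(=O)NCc1ccc(C(F)(F)F)nc1SCCOc1ccccc1)c1ccc(NS(C)(=O)=O)c(F)c1`, gives 2.3 nM in this assay. Among the measured compounds shown here, the one measured step, a 1.3-fold higher number from compound 1 to compound 2 (0.12 log units; within the scatter), swaps the group at the end of the sulfur-linked chain, so the two compounds stand on a par rather than apart.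

Compound 3 `CC1CCN(CCCSc2nc(C(F)(F)F)ccc2CNC(=O)C(C)c2ccc(NS(C)(=O)=O)c(F)c2)CC1` differs from compound 2 by methyl in place of hydrogen on a saturated ring carbon. For the measured compounds named here, no measured step touches the six-membered ring itself; the single step available changes the group that hangs on the chain, and it stayed within the scatter. With nothing in the data pointing to a change in either direction, the expectation for compound 3 is a step that is not beyond the scatter: no change at the digits printed from compound 2 to compound 3 (within the scatter). Compound 3 is therefore estimated at 3 nM in this assay, with a range from 1.2 nM to 8 nM.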

Compound 3, inhibition constant: 2.9 nM
Estimate against measurement, compound 3: 1.0-fold (0.01 log units) above, and the stated range covers the measured number.
By their numbers in this assay, from the lowest: compounds 1, 3 and 2 (each within the scatter of the next).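

In this assay, the six-membered ring now has a measured step of its own: methyl in place of hydrogen, three ring bonds from the ring nitrogen, gives a 1.0-fold lower number from compound 2 to compound 3 (0.01 log units; within the scatter), so this ring carbon takes the methyl with no step beyond the scatter. The phenoxy end of the chain and the 4-methylpiperidin-1-yl end also stand on a par, with a 1.3-fold higher number from compound 1 to compound 3 (0.10 log units; within the scatter), which widens the range of end groups that read alike in this series. Nothing available here explains why these groups read alike.

Still open, on these data alone, is how a hydroxyl, a carboxylic acid or a phenyl group on that same ring carbon would read. Also open, as far as these compounds go, is whether a shorter chain to the sulfur, or an open-chain amine such as dimethylamino in place of the ring, would stay on a par.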